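From compound 3 to compound 4: methoxy on the phenyl

The compounds below may be only part of what the source reports. "The series", "measured", "known", "first", "only" and "open" are said of these compounds alone.

Measured in an ADME assay on WI-38 cells (Homo sapiens) for cytotoxicity, read by MTT assay, with a stated time of 72 h (on this read-out higher numbers stand for weaker inhibition and lower numbers for stronger inhibition), so far:
compound 1 `O=C(CCc1cccc2c1B(O)OC2)Nc1cccc(Br)c1` gives 20000 nM
compound 2 `CC(C)c1cccc(NC(=O)CCc2cccc3c2B(O)OC3)c1` gives 22000 nM
compound 3 `O=C(CCc1cccc2c1B(O)OC2)Nc1cccc(-c2ccccc2)c1` gives 12000 nM

Compound 3 lies within the scatter of the other two compounds, as shown by a 1.7-fold lower number from compound 1 to compound 3 (0.22 log units; within the scatter) and by a 1.8-fold lower number from compound 2 to compound 3 (0.26 log units; within the scatter) in this series. Compound 4 `COc1ccc(-c2cccc(NC(=O)CCc3cccc4c3B(O)OC4)c2)cc1` differs from it by methoxy in place of hydrogen on an aromatic carbon and so has methoxy in place of hydrogen on an aromatic carbon, para to a large group. Within the data shown here, no measured step adds a methoxy. The closest evidence is the exchange of bromo, isopropyl and phenyl, which also gave a 1.1-fold higher number from compound 1 to compound 2 (0.04 log units; within the scatter) and stayed within the scatter throughout. No step beyond the scatter is therefore expected in this assay for this change. The expected step is a 1.1-fold lower number from compound 3 to compound 4 (0.04 log units; within the scatter) and no larger one is anticipated. Compound 4 is estimated at 11000 nM with an expected range of 5500 nM to 22000 nM in this measurement.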

Compound 4, half-maximal inhibitory concentration: 1400 nM
For compound 4 the middle estimate is 7.9-fold (0.90 log units) above the measured one; the whole stated range lies above it.
By their numbers in this assay, from the lowest: compound 4; then compounds 3, 1 and 2 (each within the scatter of the next).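

In this assay, among these compounds, the change from phenyl to 4-methoxyphenyl gives an 8.6-fold lower number from compound 3 to compound 4 (0.93 log units; beyond the scatter) and is the first step here beyond the scatter, since exchanges among bromo, isopropyl and phenyl all stayed within it. The gaps to the earlier groups are larger still, with a 16-fold lower number from compound 2 to compound 4 (1.20 log units; beyond the scatter) and a 14-fold lower number from compound 1 to compound 4 (1.15 log units; beyond the scatter) in this series. Nothing available explains why this substitution moves the number.

The compounds shown leave open whether methoxy itself matters or whether hydroxy, an amine or a longer alkoxy chain at this place would do the same. They also leave open how a methoxy elsewhere on the phenyl would read.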